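Toward a Branched Methoxyphenyl Variant in the Tolerance Series

The source may report more compounds than this note shows. Statements on the series, on what has been measured and on what is new or still open speak of the compounds shown alone.

Measured so far:
compound 1: `Cc1ccc2[nH]c(=O)c(CN(Cc3ccccc3)Cc3ccc(C(C)(C)C)cc3)cc2c1` — > 5000 nM
compound 2: `Cc1ccc2[nH]c(=O)c(CN(Cc3ccc(OC(F)(F)F)cc3)Cc3ccc(C(C)(C)C)cc3)cc2c1` — > 5000 nM

Of the compounds shown here, two have been tested in a toxicity assay on MDCK cells (Canis lupus familiaris) for cytotoxicity, read by crystal violet staining, with a stated time of 48 h; a higher number here means that more compound is tolerated, a lower number that less compound is tolerated. Compound 1 carries the structure `Cc1ccc2[nH]c(=O)c(CN(Cc3ccccc3)Cc3ccc(C(C)(C)C)cc3)cc2c1`. In this assay compound 1 reaches only > 5000 nM, which is a limit of the measurement and not a number. Compound 2, `Cc1ccc2[nH]c(=O)c(CN(Cc3ccc(OC(F)(F)F)cc3)Cc3ccc(C(C)(C)C)cc3)cc2c1`, stands in the same position. In this assay compound 2 gives > 5000 nM, again a limit rather than a measured value. The step that the two limits leave unreadable from compound 1 to compound 2 can therefore not be sized, because the limit of > 5000 nM in this assay, at which 2 of the 2 values shown sit, holds both values.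

Compound 3, `COc1ccc(C(C)N(Cc2ccc(C(C)(C)C)cc2)Cc2cc3cc(C)ccc3[nH]c2=O)cc1`, has not yet been measured in this assay. It differs from compound 2 in one place: 1-(4-methoxyphenyl)ethyl in place of 4-(trifluoromethoxy)benzyl on an amine nitrogen. Among the measured compounds shown here, the only measured step, a step that the two limits leave unreadable from compound 1 to compound 2, carries no readable size, so nothing can be transferred from it to this new change. Compound 3 is expected to sit near 6000 nM, within a range from 2500 nM to 15000 nM, most likely again reported as a limit. The expected step that the limit leaves unreadable from compound 2 to compound 3 is estimated to lie within the scatter.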

Compound 3, half-maximal cytotoxic concentration: > 5000 nM
Compound 3: a limit, no number (the forecaster's own chance of this, stated with the estimate: 75%); the middle value does not contradict the limit.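

In this assay compound 3 gives > 5000 nM, a limit and not a number. Among the compounds shown here, no step from compound 1 or compound 2 to compound 3 can be read, because one limit holds all the values: the limit of > 5000 nM in this assay, at which 3 of the 3 values shown sit. The compounds shown leave open where the half-maximal cytotoxic concentration of each actually lies, and whether the changes on the amine nitrogen alter it at all.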